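Aryl Urea Change from Compound 3 to Compound 4

A few compounds are considered here, and "the series" means these few. Any claim that something is new, unique, unknown or untested is made for them only; others in the source may bear on it.

Compounds measured in a functional assay (aorta) with Rattus norvegicus as the target; a higher number here means that more compound is needed for the effect, a lower number that less compound is needed:
Compound 1 `COc1cccc(NC(=O)NC2CC(C)(C)Oc3ccc(F)cc32)c1` gives only a limit, > 10000 nM.
Compound 2 `COc1cccc(NC(=O)NC2CC(C)(C)Oc3ccc(Cl)cc32)c1` gives only a limit, > 10000 nM.
Compound 3 `COc1cccc(NC(=O)NC2CC(C)(C)Oc3ccc(Br)cc32)c1` gives only a limit, > 10000 nM.

Compound 3 thus stands at the limit of this assay, together with the other two measured compounds (the limit of > 10000 nM in this assay, at which 3 of the 3 values shown sit). The steps a step that the two limits leave unreadable from compound 1 to compound 2, a step that the two limits leave unreadable from compound 1 to compound 3 and a step that the two limits leave unreadable from compound 2 to compound 3 are all unreadable for that reason. Compound 4 `Cc1ccccc1NC(=O)NC1CC(C)(C)Oc2ccc(Br)cc21` differs from compound 3 by 2-methylphenyl in place of 3-methoxyphenyl on an amide-type nitrogen. Among the measured compounds shown here, no measured step touches the aryl group on the urea, so none bears directly on this change. With compound 3 at > 10000 nM, compound 4 is expected to sit near the limit again, the estimated step being a step that the limit leaves unreadable from compound 3 to compound 4. Compound 4 is therefore estimated at 15000 nM, within 3000 nM to 60000 nM.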

Compound 4, half-maximal effective concentration: > 30000 nM
Compound 4: only a limit was reported; the forecaster's own chance of this, stated with the estimate: 70%; middle value at least 2.0-fold (0.30 log units) from the limit.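

In this assay, among the compounds shown here, compound 4 gives only a limit, > 30000 nM, and with compound 3 also reported only as a limit, no step between the two can be read. The compounds shown leave open how any of them would compare with a measurable effective concentration.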